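The source may report more compounds than this note shows. Statements on the series, on what has been measured and on what is new or still open speak of the compounds shown alone.

Of the compounds shown here, two that share one core have been tested in an assay on thoracic aorta (strain Wistar) for antagonist activity at Adrenergic receptor alpha-1 (Rattus norvegicus), with a stated time of 30 min; on this read-out lower numbers stand for tighter binding and higher numbers for weaker binding. Compound 1 `COc1cc2nc(CNc3ccc([N+](=O)[O-])cc3)nc(N)c2cc1OC` gives 0.417 nM. Going by the values given here, compound 2 `CCN1CCN(c2nc(N)c3cc(OC)c(OC)cc3n2)CC1` gives 0.0389 nM in this assay, the lower of the two numbers, and the gap to compound 1, its only neighbour, lies well beyond the scatter. Compound 3 `COc1cc2nc(N3CCN(c4ccccc4F)CC3)nc(N)c2cc1OC` is not yet measured; it differs from compound 2 by 2-fluorophenyl in place of ethyl on an amine nitrogen in a ring. Among the compounds with values here, no measured pair shows such a change, so the expected step is a modest one, probably weakening and possibly within the scatter. Compound 3 is expected to give 0.09 nM in this assay, between 0.015 nM and 0.5 nM. The expected step is a 2.3-fold higher number from compound 2 to compound 3 (0.36 log units; beyond the scatter).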

Compound 3, dissociation constant: 0.0309 nM
For compound 3 the middle estimate is 2.9-fold (0.46 log units) above the measured one, within the range that was stated.
By their numbers in this assay, from the lowest: compounds 3 and 2 (each within the scatter of the next); then compound 1.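

In this assay 2-fluorophenyl in place of ethyl on an amine nitrogen in a ring gives a 1.3-fold lower number from compound 2 to compound 3 (0.10 log units; within the scatter) and so the two compounds cannot be told apart. At this position, then, a group of 7 heavy atoms with an aromatic ring serves as well as one of 2 heavy atoms with no ring. Nothing available here explains this. As far as these compounds go, whether unsubstituted phenyl would give a similar number, and so what part the fluorine plays, remains open. So does the outcome with a carboxylic acid or a longer chain on that nitrogen.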